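The source may hold more compounds than are shown below. What is called first, only, known or untested is meant among the compounds shown, and "the series" means these compounds.

Measured so far in a functional assay on SW480 cells (Homo sapiens) for cytotoxicity, read by MTT assay, with a stated time of 72 h; on this read-out lower numbers stand for stronger inhibition and higher numbers for weaker inhibition:
Compound 1 `O=c1cc(CSc2nc3ccccc3s2)oc2ccc(Cl)cc12`, which gives > 25000 nM, a limit of the assay and not a number.
Compound 2 `Cc1ccc2oc(CSc3nc4nc(C)cc(C)n4n3)cc(=O)c2c1`, which gives > 25000 nM, again a limit.
Compound 3 `Cc1cc(C)n2nc(SCc3cc(=O)c4cc(Cl)ccc4o3)nc2n1`, which gives > 25000 nM, also a limit.

Compound 4 `Cc1ccc2oc(CSc3nc4ccccc4s3)cc(=O)c2c1` has not yet been measured in this assay. It differs from compound 1 by methyl in place of chloro on an aromatic carbon. The same change, (methyl in place of chloro on an aromatic carbon), has already been made from compound 3 to compound 2, and there it gave a step that the two limits leave unreadable from compound 3 to compound 2. Compound 1 and compound 3 have different cores, and how those cores differ is not broken down here. Because all three measured values sit at the limit of > 25000 nM in this assay, at which 3 of the 3 values shown sit, the measured step gives no reading of how much methyl in place of chloro moves the value, in either direction. On that basis the step from compound 1 to compound 4 is expected to be a step that the limit leaves unreadable from compound 1 to compound 4 in this assay, which amounts to no readable change. Compound 4 is therefore expected to give 50000 nM in this assay, with a range from 20000 nM to 200000 nM, and most likely to be reported only as a limit again.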

Compound 4, half-maximal inhibitory concentration: > 25000 nM
Compound 4: a limit, no number; the forecaster's own chance of this, stated with the estimate: 85%; the middle value is on the limit's open side.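

No new step can be read between compound 1 and compound 4, as each gives a limit of the assay and not a number, and the other compounds do too: the limit of > 25000 nM in this assay, at which 4 of the 4 values shown sit. The compounds shown leave open whether methyl in place of chloro on an aromatic carbon moves the value at all in this assay, and in which direction.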